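The compounds below may be only part of what the source reports. "The series", "measured", "known", "first", "only" and "open" are said of these compounds alone.

Measured in a functional assay on SK-MEL-2 cells (Homo sapiens) for cytotoxicity; on this read-out higher numbers stand for weaker inhibition and lower numbers for stronger inhibition:
- compound 1 `Oc1nc(-c2ccccc2)cc2ccccc12`: 2570 nM
- compound 2 `Cc1ccc(-c2cc3ccccc3c(O)n2)cc1`: 5010 nM

Compound 1 lies within the scatter of compound 2, so the two numbers cannot be ranked. Compound 3 `Cc1ccc2c(O)nc(-c3ccccc3)cc2c1` keeps the core of compound 1 with a single change: methyl in place of hydrogen on an aromatic carbon. Going by the values given here, one measured step bears on it, which also puts methyl in place of hydrogen on an aromatic carbon, though at a different place: a 1.9-fold higher number from compound 1 to compound 2 (0.29 log units; within the scatter). That step stays within the scatter, so no change beyond the scatter is expected in this assay. The estimated step is a 1.2-fold higher number from compound 1 to compound 3 (0.07 log units; within the scatter). Compound 3 is estimated at 3000 nM, with an expected range from 1000 nM to 9000 nM.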

Compound 3, half-maximal inhibitory concentration: 1580 nM
Compound 3: middle estimate off by 1.9-fold (0.28 log units), on the high side; measured number inside the range.
By their numbers in this assay, from the lowest: compounds 3, 1 and 2 (each within the scatter of the next, the first and the last beyond it).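

On the six-membered aromatic ring of carbon only, methyl in place of hydrogen gives a 1.6-fold lower number from compound 1 to compound 3 (0.21 log units; within the scatter) in this assay. A methyl at this place therefore leaves the number within the scatter, as the methyl of compound 2 does at its own place, so neither position has yet shown a clear effect. No available evidence gives a reason for this result.

Going by these compounds, it remains open whether a different group at this position, such as an amine, a carboxylic acid or a longer chain, would move the number beyond the scatter.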